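Second ring methyl on the aryloxybutanoic acid series

A few compounds are considered here, and "the series" means these few. Any claim that something is new, unique, unknown or untested is made for them only; others in the source may bear on it.

Measured so far:
compound 1, `O=C(O)CCCOc1ccc(-c2cc(OC(F)(F)F)ccc2F)cc1`: 4220 nM
compound 2, `Cc1cc(-c2cc(OC(F)(F)F)ccc2F)ccc1OCCCC(=O)O`: 9260 nM

Both numbers come from a functional assay on isolated protein for agonist activity at Free fatty acid receptor 1 (Homo sapiens), read by HTRF and inositol phosphate accumulation, with a stated time of 60 min; on this read-out higher numbers stand for an effect only at larger amounts of compound and lower numbers for an effect already at smaller amounts. Compound 2 stands at the higher of the two numbers; compound 1 is the nearest and sits at the lower number. Among the measured compounds shown here, the one step recorded is a 2.2-fold higher number from compound 1 to compound 2 (0.34 log units; beyond the scatter), which came with methyl in place of hydrogen on an aromatic carbon of the shared core.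

Compound 3, `Cc1cc(-c2cc(OC(F)(F)F)ccc2F)cc(C)c1OCCCC(=O)O`, has not yet been measured. It differs from compound 2 by methyl in place of hydrogen on an aromatic carbon. For the measured compounds named here, only the step from compound 1 to compound 2 bears on this change; it was modest, though beyond the scatter, and pointed toward a higher number. A second methyl of the same kind is therefore expected to move the number again in the same direction by a comparable modest amount, while a step within the scatter cannot be excluded from a single precedent. For compound 3 the expected result in this assay is 16000 nM, with a range from 6500 nM to 40000 nM, an estimated step of a 1.7-fold higher number from compound 2 to compound 3 (0.24 log units; within the scatter).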

Compound 3, half-maximal effective concentration: > 9950 nM
Compound 3 gave a limit, no number (the forecaster's own chance of this, stated with the estimate: 12%); the middle value lies beyond the limit too.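

In this assay compound 3 gives > 9950 nM, which is a limit of the assay and not a number. Adding a second methyl, ortho to a 3-carboxypropoxy group and meta to the methyl group already present, gives an at least 1.0-fold higher number from compound 2 to compound 3 (0.03 log units; that floor lies within the scatter), so the result does not show a return toward a lower number, but it also leaves the size of the step unfixed: it could be no real change or a much larger rise, whereas the first methyl, at a 2.2-fold higher number from compound 1 to compound 2 (0.34 log units; beyond the scatter), had a measured size. The reading of this change is capped by the assay itself: the limit of > 9950 nM in this assay, at which 1 of the 3 values shown sits.

The compounds shown leave open how far the number actually moves with the second methyl, and whether a smaller atom such as fluorine or a group such as methoxy at this place would be tolerated any differently. They also leave open whether a longer chain in place of the 3-carboxypropoxy group, or an amide in place of its carboxylic acid, would change the response to substitution at this place.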